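The source may report more compounds than this note shows. Statements on the series, on what has been measured and on what is new or still open speak of the compounds shown alone.

Working notes on the series.

Compound 1 `COc1ccc(/C=C/C(=O)c2ccccc2-c2cccc(F)c2)cc1` gives 73 nM in a functional assay on CNE-2 cells (Homo sapiens) for antiproliferative activity, read by sulforhodamine B assay, with a stated time of 48 h; on this read-out lower numbers stand for stronger inhibition and higher numbers for weaker inhibition. Compound 2 `COc1ccc(/C=C/C(=O)c2ccccc2-c2cccc(F)c2)cc1OC` gives 650 nM in this assay; the change from compound 1 is methoxy in place of hydrogen on an aromatic carbon and the step is an 8.9-fold higher number from compound 1 to compound 2 (0.95 log units; beyond the scatter). Compound 3 `O=C(/C=C/c1ccccc1-c1ccc(F)cc1)c1cccc(O)c1` is built on a different core; the difference between its core and that of compound 1 is not broken down here. In this assay compound 3 gives 7300 nM, the highest number of the three measured compounds.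

Compound 4 `COc1ccc(C(=O)/C=C/c2ccccc2-c2ccc(F)cc2)cc1O` is not yet measured. Its change from compound 3 is methoxy in place of hydrogen on an aromatic carbon, the same kind of change as that from compound 1 to compound 2, but not the same: the new methoxy in compound 4 sits ortho to a hydroxy group and para to a large group, whereas in compound 2 it sits ortho to a methoxy group and meta to a large group, and the two cores differ. Among the measured compounds shown here, the one measured example of this change rests on compound 1 and compound 2 only, with an 8.9-fold higher number from compound 1 to compound 2 (0.95 log units; beyond the scatter). With the surroundings different, a smaller step is expected for compound 4, estimated at a 1.2-fold higher number from compound 3 to compound 4 (0.09 log units; within the scatter), giving an expected 9000 nM in this assay, within 3000 nM to 27000 nM.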

Compound 4, half-maximal inhibitory concentration: 750 nM
For compound 4 the middle estimate is 12-fold (1.08 log units) above the measured one; the measured number lies below the stated range.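

In this assay, methoxy in place of hydrogen on an aromatic carbon gives a 9.7-fold lower number from compound 3 to compound 4 (0.99 log units; beyond the scatter), a step in the opposite direction to the one seen with the same change on the core of compound 1. The effect of this change therefore cannot be carried from one core to the other in this series: the same change on two cores in this assay, an 8.9-fold higher number (0.95 log units; beyond the scatter) from compound 1 to compound 2 and a 9.7-fold lower number (0.99 log units; beyond the scatter) from compound 3 to compound 4, 87-fold (1.94 log units) apart, beyond the scatter of two such steps. This rests on one step per core, and the new methoxy in compound 4 sits ortho to a hydroxy group and para to a large group, a different place from that in compound 2, so the compounds shown do not separate the role of the core from that of the position on the ring.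

Going by these compounds, it remains open whether the gain from compound 3 to compound 4 depends on the methoxy itself or would also appear with an ethoxy group or an amine at the same place. On these data alone, it also remains open whether that gain needs the hydroxy group, which could be tested with a methoxy group or an amine in its place.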